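Working notes: from compound 3 to compound 4

This account rests on a few compounds, and the source may have more. Where it says the series, first, only, none or still open, it means among the compounds named here.

In a functional assay on HCT-116 cells (Homo sapiens) for antiproliferative activity, read by MTT assay, with a stated time of 48 h (on this read-out lower numbers stand for stronger inhibition and higher numbers for weaker inhibition), compound 1 `COc1ccc(N(C)c2ccnc(Cl)n2)cc1Cl` gives 1170 nM and compound 2 `COc1ccc(N(C)c2ccnc(Cl)n2)cc1O` gives 422 nM. The hydroxy exchange is a 2.8-fold lower number from compound 1 to compound 2 (0.44 log units; beyond the scatter).

Compound 3 `COc1ccc(N(C)c2ccnc(Cl)n2)cc1OCCCCCBr` reads > 10000 nM in this assay, which is a limit and not a number. It therefore stands at the limit of > 10000 nM in this assay, at which 1 of the 3 values shown sits, and cannot be placed more exactly.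

Compound 4 `COc1ccc(N(C)c2ccnc(Cl)n2)cc1OCC[Se]C#N` differs from compound 3 as follows: a group of 3 heavy atoms (1 carbon, 1 nitrogen, 1 selenium; no ring) in place of a group of 4 heavy atoms (3 carbon, 1 bromine; no ring), on a saturated chain carbon, two bonds along the chain from an oxygen on an aromatic ring. Going by the values given here, no measured step covers this exchange. The nearest evidence is the pair of steps leading to compound 3, namely an at least 8.5-fold higher number from compound 1 to compound 3 (0.93 log units; beyond the scatter) and an at least 23-fold higher number from compound 2 to compound 3 (1.37 log units; beyond the scatter). Among the compounds with values here, both are open-ended, and they show only that the number rose with the 5-bromopentyl ether. Compound 4 keeps a chain on that oxygen but loses the bromine-bearing end, so a partial return toward compound 1 is expected, with wide uncertainty. The expected step is an at least 6.6-fold lower number from compound 3 to compound 4 (0.82 log units; beyond the scatter). Compound 4 is estimated at 1500 nM, with an expected range from 200 nM to 8000 nM.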

Compound 4, half-maximal inhibitory concentration: 1220 nM
Compound 4: middle estimate off by 1.2-fold (0.09 log units), on the high side, and the stated range covers the measured number.
By their numbers in this assay, from the lowest: compound 2; then compounds 1 and 4 (each within the scatter of the next). At a limit, above all of these: compound 3.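

Compound 3 remains a limit and not a number: the limit of > 10000 nM in this assay, at which 1 of the 4 values shown sits.

In this assay, an at least 8.1-fold lower number from compound 3 to compound 4 (0.91 log units; beyond the scatter) shows that an ether chain on this oxygen does not by itself hold the read-out at that limit, so the chain and its end matter together. The remaining steps place the new ether relative to the two simple substituents: a 1.0-fold higher number from compound 1 to compound 4 (0.02 log units; within the scatter), so it cannot be told apart from the chloro compound, while a 2.9-fold higher number from compound 2 to compound 4 (0.46 log units; beyond the scatter), so the free hydroxy compound keeps the lower number.

The exchange alters both chain length and chain end, and the compounds shown do not separate these two changes. A 2-bromoethyl ether, a pentyl chain ending in the same selenium and nitrile group, or a chain ending in an amine would each bear on that question.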